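The compounds below may be only part of what the source reports. "The series", "measured", "known", "first", "only" and "open" are said of these compounds alone.

In an assay on HL-60 cells for inhibition of glutathione S-transferase P (Homo sapiens) (a lower number here means a stronger inhibitor, a higher number a weaker inhibitor), compound 3 `C=C(CC)C(=O)c1ccc(OCc2nc(C)no2)c(Cl)c1Cl` gives 4000 nM, the highest of the three numbers measured; its gap to compound 1 `C=C(C)C(=O)c1ccc(OCc2nc(-c3ccccc3)no2)cc1C`, which gives 1970 nM, lies beyond the scatter, whereas compound 2 `C=C(C)C(=O)c1ccc(OCc2nc(-c3ccc([N+](=O)[O-])cc3)no2)cc1C`, which gives 2900 nM, sits within the scatter of compound 3. Compound 4 `C=C(CC)C(=O)c1ccc(OCc2nc(-c3ccc(C(F)(F)F)cc3)no2)c(Cl)c1Cl` differs from compound 3 by 4-(trifluoromethyl)phenyl in place of methyl on an aromatic carbon, on the carbon between two ring nitrogen atoms. Among the compounds with values here, the only measured step touching that aryl group is a 1.5-fold higher number from compound 1 to compound 2 (0.17 log units; within the scatter), so a substituent change on that ring left this assay essentially unchanged; no measured pair compares methyl with an aryl group at this position. Compound 4 is therefore expected to land near compound 3, with a step of a 1.3-fold lower number from compound 3 to compound 4 (0.12 log units; within the scatter) that stays within the scatter, and its estimated value is 3000 nM, ranging from 1200 nM to 7500 nM.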

Compound 4, half-maximal inhibitory concentration: > 40000 nM
Compound 4 gave a limit, no number; the forecaster's own chance of this, stated with the estimate: 5%; middle value at least 13-fold (1.12 log units) away from the limit.
By their numbers in this assay, from the lowest: compounds 1, 2 and 3 (each within the scatter of the next, the first and the last beyond it). At a limit, above all of these: compound 4.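

At the carbon between two ring nitrogen atoms, 4-(trifluoromethyl)phenyl in place of methyl gives an at least 10-fold higher number from compound 3 to compound 4 (1.00 log units; beyond the scatter), so in this assay this position responds strongly to the change. The earlier step on the outer ring, a 1.5-fold higher number from compound 1 to compound 2 (0.17 log units; within the scatter), gave no sign of such a response. The reading for compound 4 is a limit of the assay, not a number: the limit of > 40000 nM in this assay, at which 1 of the 4 values shown sits.

The compounds shown leave open whether the ring itself or its trifluoromethyl carries this step. They also leave open how a plain phenyl, an ethyl chain or an amine on that carbon would read on the core of compound 3.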